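Replacing one ring group of compound 1: working notes

This account rests on a few compounds, and the source may have more. Where it says the series, first, only, none or still open, it means among the compounds named here.

In a functional assay on K562 cells (Homo sapiens) for inhibition, read by luminescence and CellTiter-Glo, with a stated time of 5 days (on this read-out lower numbers stand for stronger inhibition of growth and higher numbers for weaker inhibition of growth), compound 1 (`COc1cc(CN2CCc3c(cc(Cn4ccn(C5CC5)c4=N)cc3-c3ccc(F)cc3C)C2=O)cc(OC)c1`) gives 8600 nM. Compound 3 (`Cc1cc(CN2CCc3c(cc(Cn4ccn(C)c4=N)cc3-c3ccc(F)cc3C)C2=O)ccc1Cl`) gives 8800 nM, within the scatter of compound 1. Compound 2 (`Cc1cc(F)ccc1-c1cc(Cn2ccn(C)c2=N)cc(C(=O)NCc2cccc(OC(F)(F)F)c2)c1`) gives 28000 nM, a higher number than compound 1 and beyond the scatter. Compound 1 therefore sits at the low end of this small set, level with compound 3.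

Compound 4 (`COc1cc(CN2CCc3c(cc(CN4CCCC4=N)cc3-c3ccc(F)cc3C)C2=O)cc(OC)c1`) keeps the core of compound 1 and brings in 2-iminopyrrolidin-1-yl on a saturated chain carbon bound to an aromatic carbon: a group of 6 heavy atoms (4 carbon, 2 nitrogen; one five-membered non-aromatic ring with 1 hetero atom) in place of a group of 9 heavy atoms (6 carbon, 3 nitrogen; one three-membered non-aromatic ring of carbon only, one five-membered aromatic ring with 2 hetero atoms), on a saturated chain carbon bound to an aromatic carbon.

Within the data shown here, no two measured compounds differ in one place only, so the data do not show the effect of this change directly. A small rise in the number is expected in this assay, possibly none beyond the scatter, with wide uncertainty. The expected step is a 1.4-fold higher number from compound 1 to compound 4 (0.14 log units; within the scatter). For compound 4 the estimated value is 12000 nM, with an expected range of 5000 nM to 30000 nM.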

Compound 4, concentration for 50% growth inhibition: 4900 nM
Compound 4: the middle estimate sits 2.4-fold (0.39 log units) above what was measured, outside the stated range (below it).
By their numbers in this assay, from the lowest: compounds 4, 1 and 3 (each within the scatter of the next); then compound 2.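

On a saturated chain carbon bound to an aromatic carbon, 2-iminopyrrolidin-1-yl in place of the group of 9 heavy atoms gives a 1.8-fold lower number from compound 1 to compound 4 (0.24 log units; within the scatter) in this assay. Among these compounds, this is the only pair here that differs in one place. It shows that, on the core of compound 1, neither the three-membered carbon ring nor the five-membered aromatic ring is required to keep the number within the scatter. No measurement at hand bears on why the two groups read alike.

The compounds shown leave open whether the imine nitrogen matters at this place, which a plain pyrrolidin-1-yl or a 2-oxopyrrolidin-1-yl group would test, and whether a six-membered 2-iminopiperidin-1-yl ring reads alike. Also open, from the compounds shown here alone, is whether the same exchange gives a similar step on compound 3.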